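A few compounds are considered here, and "the series" means these few. Any claim that something is new, unique, unknown or untested is made for them only; others in the source may bear on it.

Three compounds share a core and were followed in an ADME assay on the whole organism (Macaca fascicularis) for pharmacokinetics, read by LC-MS, using cassette dosing, at a dose of 1 mg/kg by the oral route; on this read-out higher numbers stand for higher exposure at the dose given and lower numbers for lower exposure. Compound 1 `Cc1ccc(-c2nc(=O)o[nH]2)c(-c2ccc([C@@H](C)N(CC3CC3)c3nc4c(C(=O)O)cccc4o3)cc2)c1` gives 4830 ng.h/mL, and compound 2 `C[C@H](c1ccc(-c2cc(F)ccc2-c2nc(=O)o[nH]2)cc1)N(CC1CC1)c1nc2c(C(=O)O)cccc2o1` gives 4410 ng.h/mL; these two numbers lie within the scatter of each other, as the step of a 1.1-fold lower number from compound 1 to compound 2 (0.04 log units; within the scatter) shows. Compound 3 `CCCCN(c1nc2c(-c3nccn3C)cccc2o1)[C@H](C)c1ccc(-c2ccccc2-c2nnn[nH]2)cc1`, built on a differently substituted core, gives 152 ng.h/mL, far below both. On the numbers shown, compound 2 therefore stands together with compound 1 and well clear of compound 3.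

Compound 4 `C[C@H](c1ccc(-c2ccccc2-c2nc(=O)o[nH]2)cc1)N(CC1CC1)c1nc2c(C(=O)O)cccc2o1` has not yet been measured. It differs from compound 2 by hydrogen in place of fluoro on an aromatic carbon. For the measured compounds named here, the one measured step that touches the same position is a 1.1-fold lower number from compound 1 to compound 2 (0.04 log units; within the scatter), where one small group replaced another on that aromatic carbon without moving the number beyond the scatter. Going by the values given here, nothing among the measured compounds suggests that removing the fluoro at this site should matter; the large drop to compound 3 comes with many changes at once and bears little on this step. The expected step is a 1.0-fold higher number from compound 2 to compound 4 (0.01 log units; within the scatter), that is, none beyond the scatter. Compound 4 is accordingly estimated to give about 4500 ng.h/mL, within a range from 2200 ng.h/mL to 9000 ng.h/mL.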

Compound 4, area under the concentration-time curve: 11600 ng.h/mL
Beside the measured number, compound 4's estimate is 2.6-fold (0.41 log units) below it; the measured number lies above the stated range.
By their numbers in this assay, from the lowest: compound 3; then compounds 2 and 1 (each within the scatter of the next); then compound 4.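

The aromatic carbon meta to a large group and para to a group of 6 heavy atoms proves able to shift the exposure read-out in this assay after all: hydrogen in place of fluoro gives a 2.6-fold higher number from compound 2 to compound 4 (0.42 log units; beyond the scatter) and is beyond the scatter, while hydrogen in place of methyl gives a 2.4-fold higher number from compound 1 to compound 4 (0.38 log units; beyond the scatter) and is also beyond it, both being modest. For the compounds shown here, the earlier step (a 1.1-fold lower number from compound 1 to compound 2 (0.04 log units; within the scatter)) compared only two small groups on this carbon, so it could not show that fluoro and methyl stand together on one side and hydrogen on the other, which is what these compounds now show. Nothing at hand says why the exposure differs between hydrogen and these two groups.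

Going by these compounds, whether a larger or differently built group on this carbon, such as an amine, a carboxylic acid or a longer chain, would go with hydrogen or with fluoro and methyl remains open. Also open, on these data alone, is whether hydrogen in place of fluoro would give a step of this size on the differently substituted core of compound 3.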